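From Diethylamino to Fluoro on the Benzyl Ring

The compounds below may be only part of what the source reports. "The series", "measured", "known", "first", "only" and "open" are said of these compounds alone.

In an assay on HEK293 cells for antagonist activity at Toll-like receptor 9 (Homo sapiens), read by spectrophotometry (on this read-out lower numbers stand for stronger inhibition and higher numbers for weaker inhibition), two compounds have been measured:
Compound 1, `CCN1CCN(CCCn2cnc3c(N4CCN(CC)CC4)nc(N)nc32)CC1`: 260 nM
Compound 2, `CCN1CCN(CCCn2cnc3c(N4CCN(CC)CC4)nc(NCc4ccc(N(CC)CC)cc4)nc32)CC1`: 440 nM

Among the measured compounds shown here, compound 2 gives the higher of these two numbers, and compound 1 is its only neighbour. For the measured compounds named here, the single measured step, a 1.7-fold higher number from compound 1 to compound 2 (0.23 log units; within the scatter), does not exceed the scatter, so the two compounds cannot be told apart on potency.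

Compound 3, `CCN1CCN(CCCn2cnc3c(N4CCN(CC)CC4)nc(NCc4ccc(F)cc4)nc32)CC1`, differs from compound 2 in one place: fluoro in place of diethylamino on an aromatic carbon. Going by the values given here, no measured step touches the group on this benzyl ring; the one step available concerns the whole benzyl group entering rather than its substituent. There is therefore no guide from the data pointing in either direction, and the expectation in this assay is a step no larger than the scatter, a 1.0-fold higher number from compound 2 to compound 3 (0.01 log units; within the scatter). Compound 3 is estimated at 450 nM, with a range from 150 nM to 1400 nM.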

Compound 3, half-maximal inhibitory concentration: 470 nM
Compound 3: middle estimate off by 1.0-fold (0.02 log units), on the low side; the measured number falls inside the stated range.
By their numbers in this assay, from the lowest: compounds 1, 2 and 3 (each within the scatter of the next).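

On the benzyl ring, diethylamino (5 heavy atoms, 1 hydrogen-bond acceptor) and fluoro (1 heavy atom, 0 hydrogen-bond acceptors) cannot be told apart in this assay (a 1.1-fold higher number from compound 2 to compound 3 (0.03 log units; within the scatter)). Placing the whole 4-fluorobenzyl group on the nitrogen in place of hydrogen also stays within the scatter (a 1.8-fold higher number from compound 1 to compound 3 (0.26 log units; within the scatter)), so two quite different benzyl groups at this nitrogen both remain indistinguishable from compound 1. Nothing available here explains why these changes leave the read-out so little altered.

Going by these compounds, it remains open whether any group on this ring can move the number beyond the scatter, such as a carboxylic acid or a primary amine in place of fluoro. On these data alone, it is equally open whether a longer chain between the ring and the nitrogen would do so.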